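Replacing the pyrrolidin-1-yl group of compound 2

The source may report more compounds than this note shows. Statements on the series, on what has been measured and on what is new or still open speak of the compounds shown alone.

In a functional assay on KB cells (Homo sapiens) for cytotoxicity, read by MTT assay, with a stated time of 72 h (a lower number here means a stronger inhibitor, a higher number a weaker inhibitor), compound 1 `O=S(=O)(c1ccccc1)c1nc2ccccc2nc1N1CCCC1` gives 35800 nM. In this assay, compound 3 `O=S(=O)(c1ccc(F)cc1)c1nc2ccccc2nc1N1CCCC1` gives 30100 nM. In this assay, compound 2 `Cc1ccc(S(=O)(=O)c2nc3ccccc3nc2N2CCCC2)cc1` gives > 50000 nM, which is a limit and not a number.

Compound 4 `Cc1ccc(S(=O)(=O)c2nc3ccccc3nc2N2CCc3ccccc3C2)cc1` carries 1,2,3,4-tetrahydroisoquinolin-2-yl in place of the pyrrolidin-1-yl of compound 2, on an aromatic carbon (1,2,3,4-tetrahydroisoquinolin-2-yl in place of pyrrolidin-1-yl on an aromatic carbon).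

Three measured steps are available: an at least 1.3-fold higher number from compound 1 to compound 2 (0.14 log units; that floor lies within the scatter), a 1.2-fold lower number from compound 1 to compound 3 (0.08 log units; within the scatter) and an at least 1.6-fold lower number from compound 2 to compound 3 (0.22 log units; that floor lies within the scatter). Each swaps a small group on an aromatic carbon elsewhere in the molecule, and all keep pyrrolidin-1-yl, so none measures this change directly. They show only that these compounds stay in a weak range, with no step shown beyond the scatter. The expected change is therefore modest, a slightly lower number at most, and the estimate is an at least 1.4-fold lower number from compound 2 to compound 4 (0.15 log units; that floor lies within the scatter). For compound 4 the expected value is 35000 nM, with an estimated range of 12000 nM to 50000 nM.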

Compound 4, half-maximal inhibitory concentration: 32100 nM
Compound 4: middle estimate off by 1.1-fold (0.04 log units), on the high side, within the range that was stated.
By their numbers in this assay, from the lowest: compounds 3, 4 and 1 (each within the scatter of the next). At a limit, above all of these: compound 2.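

In this assay, putting 1,2,3,4-tetrahydroisoquinolin-2-yl in place of pyrrolidin-1-yl on this aromatic carbon next to the ring nitrogen gives an at least 1.5-fold lower number from compound 2 to compound 4 (0.19 log units; that floor lies within the scatter), the first step shown that changes this position rather than a small group elsewhere. The larger group, with its added six-membered aromatic ring of carbon only, gives a true number, as compound 4 reads 32100 nM, but it brings no step shown beyond the scatter. Compound 2 stands at a limit, so this step is only a floor and its true size stays unknown: the limit of > 50000 nM in this assay, at which 1 of the 4 values shown sits.

Still open, on these data alone, is whether a group with a free amine at this position, such as piperazin-1-yl, would give a clearly lower number. Also open, as far as these compounds go, is how 1,2,3,4-tetrahydroisoquinolin-2-yl would read when paired with the fluoro group of compound 3.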